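A Four-Membered Ring Swapped for Another on the Shared Core

This account rests on a few compounds, and the source may have more. Where it says the series, first, only, none or still open, it means among the compounds named here.

Three compounds built on a shared core were tested in a functional assay on cells for antagonist activity at Free fatty acid receptor 1 (Homo sapiens), read by TR-FRET and inositol phosphate accumulation, with a stated time of 2 h; a lower number here means a stronger inhibitor, a higher number a weaker inhibitor. Compound 1 `Cc1cc(COc2ccccc2C#N)nc(-c2ccccn2)n1` gives 10000 nM in this assay. Compound 2 `CC(=O)Nc1cccc(OCc2cc(C)nc(-c3ccccn3)n2)c1` reaches only the limit of this assay, > 39800 nM, and no number is known for it; the same limit is recorded as the limit of > 39800 nM in this assay, at which 1 of the 3 values shown sits. Compound 3 `CC1(C)CN(c2cc(COc3ccc(F)c(F)c3F)nc(-c3ccccn3)n2)C1` gives 25.1 nM in this assay, the lowest of the two numbers that were obtained, and the gap to compound 1 lies well beyond the usual scatter.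

Compound 4 `COC1(COc2cc(COc3ccc(F)c(F)c3F)nc(-c3ccccn3)n2)COC1` has not yet been measured. It differs from compound 3 in one place: (3-methoxyoxetan-3-yl)methoxy in place of 3,3-dimethylazetidin-1-yl on an aromatic carbon. For the measured compounds named here, no measured pair in this set separates by a single change, so the size of this step cannot be read from the numbers already in hand. The account therefore rests on the change itself, which keeps a four-membered ring with one hetero atom on the aromatic carbon but exchanges the group that carries it.

Compound 4 is expected to give about 200 nM in this assay, with a range from 50 nM to 1500 nM. The expected step of an 8.0-fold higher number from compound 3 to compound 4 (0.90 log units; beyond the scatter) is thus a loss that goes somewhat beyond the scatter, toward a weaker inhibitor, while still leaving the number far from the limit seen for compound 2.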

Compound 4, half-maximal inhibitory concentration in the Free fatty acid receptor 1 assay: 501 nM
Beside the measured number, compound 4's estimate is 2.5-fold (0.40 log units) below it, and the stated range covers the measured number.
By their numbers in the Free fatty acid receptor 1 assay, from the lowest: compound 3; then compound 4; then compound 1. At a limit, above all of these: compound 2.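

For the compounds shown here, compound 3 and compound 4 form the first pair in this set that differs in one place, and in the Free fatty acid receptor 1 assay the exchange gives a 20-fold higher number from compound 3 to compound 4 (1.30 log units; beyond the scatter). Going by these compounds alone, the number at this aromatic carbon therefore responds strongly to the group it carries, something the earlier compounds, which differ in more than one place, could not show. Both groups hold a four-membered non-aromatic ring with 1 hetero atom, so keeping a ring of that size does not preserve the number when 3,3-dimethylazetidin-1-yl gives way to (3-methoxyoxetan-3-yl)methoxy. The exchange also comes with a lower reading in a physicochemical assay for lipophilicity, at pH 7.4; on this read-out higher numbers stand for higher lipophilicity and lower numbers for lower lipophilicity (compound 3 gives 4.3 and compound 4 gives 3.5), though a single pair cannot say whether the two changes are linked: the measured distribution coefficient of compound 3, 4.3, and of compound 4, 3.5, a number 0.80 log units lower (beyond the scatter)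

The compounds shown leave open which part of the entering group goes with the loss: the oxetane ring, its methoxy group or the ether oxygen that joins it to the aromatic carbon. On these data alone, an open-chain dialkylamine, a pyrrolidine or a simple alkoxy chain at this carbon would help separate these parts, and whether the step holds with other groups elsewhere on the shared core also remains unknown.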